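Swapping Methoxy for Methylsulfanyl on a Pyrimidine Thiourea

The compounds below may be only part of what the source reports. "The series", "measured", "known", "first", "only" and "open" are said of these compounds alone.

Three compounds built on the same core were tested in a functional assay on the whole organism for inhibition, with Chenopodium ficifolium as the target, with a stated time of 72 h, tested at 10 mg/L; on this read-out higher numbers stand for more inhibition of growth at the one concentration tested and lower numbers for less inhibition of growth. Compound 1 `COc1cc(C)nc(NC(=S)NC(=O)c2c(-c3ccc(Cl)cc3Cl)noc2C)n1` gives 15.3%. Compound 2 `Cc1onc(-c2ccc(Cl)cc2Cl)c1C(=O)/N=c1/nc2nc(Cl)cc(C)n2s1` gives 18.6%, and compound 3 `COc1cc(SC)nc2n/c(=N/C(=O)c3c(-c4ccc(Cl)cc4Cl)noc3C)sn12` gives 23.8%. The gaps between these three figures all lie within the usual scatter of this assay, so compound 1 cannot be set apart from compound 2 or compound 3 on these numbers; all three sit close together at the low end of what the read-out can show.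

Compound 4 `CSc1cc(C)nc(NC(=S)NC(=O)c2c(-c3ccc(Cl)cc3Cl)noc2C)n1` has not yet been measured. It differs from compound 1 in one place: methylsulfanyl in place of methoxy on an aromatic carbon. Among the compounds with values here, no measured pair in this set shows what this exact change does, so the expectation rests on the small spread seen so far. The step from compound 1 to compound 4 is expected to be small, a number 1.7 percentage points higher from compound 1 to compound 4 (within the scatter), not clearly beyond the scatter in either direction. Compound 4 is therefore estimated at 17%, with a likely range from 8% to 28%.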

Compound 4, percent growth inhibition at one concentration: 32.8%
Beside the measured number, compound 4's estimate is 15.8 percentage points below it; measured number above the stated range.
By their numbers in this assay, from the lowest: compounds 1, 2, 3 and 4 (each within the scatter of the next, the first and the last beyond it).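

In this assay, within the data shown here, methylsulfanyl in place of methoxy on the six-membered aromatic ring with 2 nitrogen gives a number 17.5 percentage points higher from compound 1 to compound 4 (beyond the scatter), the first step here that can be read as a real difference. This shows that the position is sensitive to what sits on it: exchanging one oxygen for one sulfur alters the result, although the heavy-atom and hydrogen-bond counts of the two groups are the same. No measurement shown here explains why this exchange has this effect.

Going by these compounds, it remains open whether a longer chain on the sulfur, such as ethylsulfanyl, or an amine such as dimethylamino at the same place would give more or less inhibition of growth. With a single tested concentration, it is also unknown whether this step would hold at other doses.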